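A few compounds are considered here, and "the series" means these few. Any claim that something is new, unique, unknown or untested is made for them only; others in the source may bear on it.

In a functional assay on Jurkat cells for inhibition of nuclear factor NF-kappa-B complex (Homo sapiens) (a lower number here means a stronger inhibitor, a higher number a weaker inhibitor), compound 3 `CCOC(=O)c1cnc(-c2ccc(Cl)s2)nc1NN1C(=O)C=C(C)C1=O` gives 300 nM and is the strongest of the three inhibitors described here. Compound 1 `CCOC(=O)c1cnc(-c2ccncc2)nc1NN1C(=O)C=C(C)C1=O` gives 6000 nM and compound 2 `CCOC(=O)c1cnc(-c2cccc(OC)c2)nc1NN1C(=O)C=C(C)C1=O` gives 5000 nM; between them the change is a 1.2-fold lower number from compound 1 to compound 2 (0.08 log units; within the scatter). The steps to compound 3, by contrast, were large: a 20-fold lower number from compound 1 to compound 3 (1.30 log units; beyond the scatter) and a 17-fold lower number from compound 2 to compound 3 (1.22 log units; beyond the scatter). Compound 4 `CCOC(=O)c1cnc(C(=O)c2ccco2)nc1NN1C(=O)C=C(C)C1=O` alters the same aromatic carbon once more: (furan-2-yl)carbonyl in place of 5-chlorothiophen-2-yl on an aromatic carbon. Both earlier steps show that the group at this carbon can shift this assay by a large step, and the two groups other than 5-chlorothiophen-2-yl gave compound 1 and compound 2 numbers well above compound 3, so one expects compound 4 to give a higher number, a 10-fold higher number from compound 3 to compound 4 (1.00 log units; beyond the scatter), estimated at 3000 nM within a range of 500 nM to 15000 nM.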

Compound 4, half-maximal inhibitory concentration: 700 nM
For compound 4 the middle estimate is 4.3-fold (0.63 log units) above the measured one; low and high end bracket the measured number.
By their numbers in this assay, from the lowest: compound 3; then compound 4; then compounds 2 and 1 (each within the scatter of the next).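

At this carbon between two ring nitrogen atoms, (furan-2-yl)carbonyl comes close to 5-chlorothiophen-2-yl in this assay, with a 2.3-fold higher number from compound 3 to compound 4 (0.37 log units; beyond the scatter). It still clearly improves on the other two groups, with a 7.1-fold lower number from compound 2 to compound 4 (0.85 log units; beyond the scatter) and an 8.6-fold lower number from compound 1 to compound 4 (0.93 log units; beyond the scatter). Thus, neither sulfur nor chlorine in this group is needed for a number well below those of compound 1 and compound 2.

From the compounds shown here alone, how a plain furan-2-yl or a simple amine at this carbon would compare remains open, as does what the carbonyl alone contributes. Nothing available here explains these differences.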